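Working notes: phenyl in place of furan-2-yl

The source may report more compounds than this note shows. Statements on the series, on what has been measured and on what is new or still open speak of the compounds shown alone.

- compound 1 `CC(C)(C)C1=C(C(=O)O)N2C(=O)/C(=C/c3ccco3)C2O1`: 0.22 h
- compound 2 `CC(C)(C)C1=C(C(=O)O)N2C(=O)CC2O1`: 115 h

In a physicochemical assay for pharmacokinetics, read by fluorescence and HPLC, with a stated time of 24 h (a higher number here means that the compound lasts longer, a lower number that the compound disappears faster), compound 1 gives 0.22 h, the lower of the two numbers, and compound 2 gives 115 h, a gap beyond the scatter. Compound 3 `CC(C)(C)C1=C(C(=O)O)N2C(=O)/C(=C/c3ccccc3)C2O1` has phenyl in place of furan-2-yl on a double-bonded chain carbon bound to a double-bonded ring carbon. Going by the values given here, no measured pair shows this exchange, so the expectation rests on compound 1 alone, and in this assay a slight upward move, not beyond the scatter, is expected. The estimated change is a 1.8-fold higher number from compound 1 to compound 3 (0.26 log units; within the scatter). For compound 3 the estimated half-life is 0.4 h, with an expected range of 0.12 h to 1.5 h.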

Compound 3, half-life: 0.21 h
Beside the measured number, compound 3's estimate is 1.9-fold (0.28 log units) above it; measured number inside the range.
By their numbers in this assay, from the lowest: compounds 3 and 1 (each within the scatter of the next); then compound 2.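

In this assay, phenyl in place of furan-2-yl on a double-bonded chain carbon bound to a double-bonded ring carbon gives a 1.0-fold lower number from compound 1 to compound 3 (0.02 log units; within the scatter) and so leaves the half-life within the scatter. For this pair, the oxygen of furan-2-yl is not required to keep the half-life where it stands. Nothing measured here explains this outcome.

From the compounds shown here alone, whether an amine on the phenyl would shift the half-life remains open. So does the outcome of a pyridyl ring or a longer alkyl chain in place of phenyl at this carbon.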